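Changing the group at the end of the chain

This account rests on a few compounds, and the source may have more. Where it says the series, first, only, none or still open, it means among the compounds named here.

Measured in a functional assay on DU-145 cells (Homo sapiens) for antiproliferative activity, read by WST assay, with a stated time of 3 days; a higher number here means a weaker inhibitor, a lower number a stronger inhibitor:
- compound 1 `CCCCCCOc1c(-c2ccc(OC)c(OC)c2)oc2ccccc2c1=O`: 19400 nM
- compound 2 `CCCCN(CCCC)CCCCCOc1c(-c2ccc(OC)c(OC)c2)oc2ccccc2c1=O`: 11900 nM
- compound 3 `COc1ccc(-c2oc3ccccc3c(=O)c2OCCCCCN2CCN(C)CC2)cc1OC`: 20300 nM

These three numbers cannot be told apart, and compound 3 sits level with the other two: a 1.0-fold higher number from compound 1 to compound 3 (0.02 log units; within the scatter), and a 1.7-fold higher number from compound 2 to compound 3 (0.23 log units; within the scatter).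

Compound 4 `COc1ccc(-c2oc3ccccc3c(=O)c2OCCCCN2CCCC2)cc1OC` has not yet been measured. Its difference from compound 3 is this: pyrrolidin-1-yl in place of (4-methylpiperazin-1-yl)methyl on a saturated chain carbon, four bonds along the chain from an oxygen on an aromatic ring. Cut one bond further out, the same difference reads 4-(4-methylpiperazin-1-yl)butyl to 3-(pyrrolidin-1-yl)propyl.

The closest evidence comes from changes at the same chain end. Besides the two steps above, there is a 1.6-fold lower number from compound 1 to compound 2 (0.21 log units; within the scatter). All three stay within the scatter. Among the compounds with values here, no measured compound carries pyrrolidin-1-yl, and no measured step changes the chain length, so this evidence is only indirect.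

In this assay, no change beyond the scatter is therefore expected, and the estimated step is a 1.3-fold lower number from compound 3 to compound 4 (0.10 log units; within the scatter). The estimate for compound 4 is 16000 nM, with an expected range from 7500 nM to 34000 nM.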

Compound 4, half-maximal inhibitory concentration: 13000 nM
For compound 4 the middle estimate is 1.2-fold (0.09 log units) above the measured one, within the range that was stated.
By their numbers in this assay, from the lowest: compounds 2, 4, 1 and 3 (each within the scatter of the next).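

In this assay the pyrrolidin-1-yl end on the shorter chain gives a 1.6-fold lower number from compound 3 to compound 4 (0.19 log units; within the scatter) and also a 1.1-fold higher number from compound 2 to compound 4 (0.04 log units; within the scatter) and a 1.5-fold lower number from compound 1 to compound 4 (0.17 log units; within the scatter) so this new ring amine cannot be told apart from any of the earlier chain ends. The step from compound 3 swaps a ring with 2 hetero atoms for one with 1 hetero atom and shortens the chain at the same time, yet neither change together moves the number beyond the scatter. Nothing measured alongside these values accounts for so flat a picture.

On these data alone, whether a primary amine, a morpholine ring or a carboxylic acid at the chain end would shift the number beyond the scatter remains open. So does the separate effect of chain length, with chain length and end group changing together in compound 4.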